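Reversal and removal of the amide on the pendant phenyl

The source may report more compounds than this note shows. Statements on the series, on what has been measured and on what is new or still open speak of the compounds shown alone.

Measured compounds:
compound 1 `CC(C)CC(=O)Nc1cccc(-c2ccnc3c(C(=O)c4cccs4)cnn23)c1`, 21 nM
compound 2 `CC(C)CNC(=O)c1cccc(-c2ccnc3c(C(=O)c4cccs4)cnn23)c1`, 150 nM

Among the compounds with values here, in a functional assay on LoVo cells (Homo sapiens) for antiproliferative activity (a lower number here means a stronger inhibitor, a higher number a weaker inhibitor), compound 2 gives 150 nM, the highest of the two numbers so far; the nearest is compound 1 with 21 nM. Within the data shown here, the only measured step, a 7.1-fold higher number from compound 1 to compound 2 (0.85 log units; beyond the scatter), turns the acylamino into the reversed amide on the same aromatic carbon.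

Compound 3 `CC(C)CCNc1cccc(-c2ccnc3c(C(=O)c4cccs4)cnn23)c1` continues from compound 2 with isopentylamino in place of isobutylcarbamoyl on an aromatic carbon; the carbonyl leaves entirely and the chain grows by one carbon, at the position meta to a large group. Among the measured compounds shown here, no measured step covers loss of the carbonyl, so the one step available bears on compound 3 only indirectly: it shows that this position tolerates a change of substituent at a modest cost. The step of a 1.5-fold lower number from compound 2 to compound 3 (0.18 log units; within the scatter) is therefore expected to be small in either direction, and compound 3 is estimated at 100 nM, within 20 nM to 500 nM.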

Compound 3, half-maximal inhibitory concentration: 81 nM
Compound 3: middle estimate off by 1.2-fold (0.09 log units), on the high side; low and high end bracket the measured number.
By their numbers in this assay, from the lowest: compound 1; then compounds 3 and 2 (each within the scatter of the next).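

In this assay the isopentylamino group, which has no carbonyl, cannot be told apart from the isobutylcarbamoyl group of the reversed amide (a 1.9-fold lower number from compound 2 to compound 3 (0.27 log units; within the scatter)), so a carbonyl on this side chain is not needed to hold activity at that level. Compared with the acylamino group on the same ring nitrogen, the picture differs: isopentyl in place of isobutylcarbonyl gives a modest but real loss (a 3.9-fold higher number from compound 1 to compound 3 (0.59 log units; beyond the scatter)), and compound 1 stays ahead of compound 3, so the carbonyl counts in that orientation. No measurement bears on the origin of either step.

Open, as far as these compounds go, is whether the nitrogen on the ring is itself needed, which an ether oxygen or a plain alkyl chain at this carbon would address. Also open, from the compounds shown here alone, is how a morpholine or a terminal carboxylic acid on the chain would fare here.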